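A Third Methoxy Group and the Expected Change in Cytotoxicity

A few compounds are considered here, and "the series" means these few. Any claim that something is new, unique, unknown or untested is made for them only; others in the source may bear on it.

Compound 1 `COc1ccc([C@@H]2Oc3cc(OC)c(OC)c(OC)c3C(=O)[C@@H]2O)cc1` and compound 2 `COc1ccc([C@@H]2Oc3cc(OC)c(OC)c(OC)c3C(=O)[C@@H]2O)cc1OC` are close relatives built on a shared core. In a functional assay on PC-12 cells (Rattus norvegicus) for cytotoxicity, read by MTT assay, with stated times of 2 h and 4 h, tested at 32 ug/mL (on this read-out lower numbers stand for a weaker effect and higher numbers for a stronger effect at the one concentration tested), compound 1 gives 2.1%, and compound 2 gives 2.4%. Compound 2 thus holds the higher of the two numbers shown, but the step of a number 0.3 percentage points higher from compound 1 to compound 2 (within the scatter) lies within the scatter, so the two compounds cannot really be told apart; both sit near the bottom of the scale.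

Compound 3 `COc1cc([C@@H]2Oc3cc(OC)c(OC)c(OC)c3C(=O)[C@@H]2O)cc(OC)c1OC` differs from compound 2 by methoxy in place of hydrogen on an aromatic carbon. Among the measured compounds shown here, the only measured step that bears on this change is a number 0.3 percentage points higher from compound 1 to compound 2 (within the scatter), which is the same kind of change, methoxy in place of hydrogen on an aromatic carbon, and it produced no movement beyond the scatter. For the measured compounds named here, no other step is available.

On that basis no shift beyond the scatter is expected in this assay. The step from compound 2 to compound 3 is estimated at a number 0.1 percentage points higher from compound 2 to compound 3 (within the scatter). Compound 3 is therefore expected to give about 2.5%, with a likely range from 0% to 9%.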

Compound 3, a percentage reported as activity, at one concentration (the size of the read-out at that concentration, not a potency): 15.1%
For compound 3 the middle estimate is 12.6 percentage points below the measured one; measured number above the stated range.
By their numbers in this assay, from the lowest: compounds 1 and 2 (each within the scatter of the next); then compound 3.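

In this assay the same swap, methoxy in place of hydrogen on an aromatic carbon, does not have one fixed size: it gave a number 0.3 percentage points higher from compound 1 to compound 2 (within the scatter) the first time and a number 12.7 percentage points higher from compound 2 to compound 3 (beyond the scatter) the second time. So among these three compounds, the effect of adding a methoxy group depends on the compound that receives it, and here the step beyond the scatter belongs to the group placed ortho to a methoxy group, meta to a second methoxy group and meta to a large group on the same ring. Nothing measured here gives the reason why this addition moves the number while the earlier one did not.

The compounds shown leave open whether the rise is tied to methoxy itself or would also appear with another group at this place, such as a hydroxyl, an amine or a longer chain like ethoxy. They also leave open how compound 3 would behave at other concentrations, since its 15.1% comes from a single concentration and describes the size of the effect there, not a potency.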